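The source may report more compounds than this note shows. Statements on the series, on what has been measured and on what is new or still open speak of the compounds shown alone.

Compound 1 `COc1cccc(NC(=S)NC2CC(C)(C)Oc3ccc(Br)cc32)c1` gives 87000 nM.
Compound 2 `CC1(C)CC(NC(=S)Nc2cccc(C#N)c2)c2cc(Cl)ccc2O1` gives 10000 nM.
Compound 3 `COc1ccc(Cl)cc1CNC(=S)Nc1cccc([N+](=O)[O-])c1` gives "not determined" (no result reported).

These thiourea compounds were examined in a functional assay on T98G cells (Homo sapiens) for inhibition, read by MTT assay, with a stated time of 72 h; a higher number here means a weaker inhibitor, a lower number a stronger inhibitor. Of the two numbers recorded, compound 1 stands highest with 87000 nM. Compound 2 gives 10000 nM, a lower number whose gap to compound 1 lies beyond the usual scatter. For compound 3 the result is "not determined" (no result reported), so no number is available for it.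

Compound 4 `CC1(C)CC(NC(=S)Nc2ccccc2Cl)c2cc(Br)ccc2O1` has not yet been measured in this assay. It keeps the core of compound 1 and differs from it in one place: 2-chlorophenyl in place of 3-methoxyphenyl on an amide-type nitrogen. Among the compounds with values here, no step between two measured compounds of this set covers this change, so its size is uncertain. What is known is that compound 2, with another substituent on the amide-type nitrogen and another halogen on the core, gives 10000 nM, a clearly lower number than compound 1. On that basis a moderate step towards a lower number is expected for compound 4, estimated as a 2.9-fold lower number from compound 1 to compound 4 (0.46 log units; beyond the scatter). That expected step would lie beyond the scatter yet fall short of the gap seen for compound 2. Compound 4 is therefore estimated at 30000 nM, with a range from 8000 nM to 120000 nM.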

Compound 4, half-maximal inhibitory concentration: 8000 nM
Compound 4: middle estimate off by 3.8-fold (0.57 log units), on the high side; measured number inside the range.
By their numbers in this assay, from the lowest: compounds 4 and 2 (each within the scatter of the next); then compound 1.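

In this assay, placing 2-chlorophenyl instead of 3-methoxyphenyl on the amide-type nitrogen, with the shared core unchanged, gives an 11-fold lower number from compound 1 to compound 4 (1.04 log units; beyond the scatter). The earlier compounds shown here offered no such reading: compound 1 and compound 2 differ in more than one place, which left the share of their gap belonging to this nitrogen substituent unknown, whereas this single change shows that the substituent alone can produce a large step beyond the scatter. No supporting measurement bears on why the number falls, and the step itself gives no explanation for it.

The change swaps both the identity of the group on the phenyl ring and its numbered place, and the compounds shown cannot tell these two contributions apart. They also leave open whether the step would carry over to a core bearing chlorine instead of bromine, and how the number would respond if an amine or a carboxylic acid stood on that phenyl ring in place of the chlorine.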